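The source may report more compounds than this note shows. Statements on the series, on what has been measured and on what is new or still open speak of the compounds shown alone.

Within the data shown here, in a functional assay on NCI-H460 cells (Homo sapiens) for inhibition, read by MTT assay, with a stated time of 24 h, tested at 1 ug/mL (on this read-out lower numbers stand for less inhibition of growth and higher numbers for more inhibition of growth at the one concentration tested), two compounds have numbers so far. Compound 1 `O=C(CCCCC(CCSC(=O)c1ccccc1)SC(=O)c1ccccc1)Nc1ccccc1` gives 5.93% and compound 2 `O=C(CCCCC(CCSC(=O)c1ccccc1)SC(=O)c1ccccc1)Nc1ccccc1Cl` gives 14.4% on the same scale. Once the usual scatter of repeated measurements is allowed for, compound 2 stands level with compound 1, and neither can be ranked above the other. Among the measured compounds shown here, the one measured step puts chloro in place of hydrogen on an aromatic carbon, and it reads a number 8.5 percentage points higher from compound 1 to compound 2 (within the scatter) in the data.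

The next compound to consider is compound 3 `O=C(CCCCC(CCSC(=O)c1ccccc1)SC(=O)c1ccccc1)Nc1cccc(Cl)c1`, which has the same atoms as compound 2, joined differently (3-chlorophenyl in place of 2-chlorophenyl on an amide-type nitrogen). It carries 3-chlorophenyl in place of 2-chlorophenyl on an amide-type nitrogen. For the measured compounds named here, no measured pair shows this kind of swap directly, so the only guide is the step of a number 8.5 percentage points higher from compound 1 to compound 2 (within the scatter) seen when the chloro group was introduced, and that step stayed inside the scatter. The step expected here is therefore a number 2.4 percentage points lower from compound 2 to compound 3 (within the scatter) and no real shift in either direction is anticipated. For compound 3 the estimated value is 12% with an expected range from 4% to 24% in this measurement.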

Compound 3, percent growth inhibition at one concentration: 9.48%
For compound 3 the middle estimate is 2.5 percentage points above the measured one; the range from low to high includes it.
By their numbers in this assay, from the lowest: compounds 1, 3 and 2 (each within the scatter of the next).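

Within this assay, moving the chlorine on the ring attached to the amide-type nitrogen, with 3-chlorophenyl in place of 2-chlorophenyl, gives a number 4.9 percentage points lower from compound 2 to compound 3 (within the scatter) and so does not separate these two groups. Placing chloro on the phenyl ring of compound 1 in this second way gives a number 3.6 percentage points higher from compound 1 to compound 3 (within the scatter) and again produces no readable change, so neither chlorophenyl group can be ranked above the plain phenyl group at the one concentration tested. Nothing available explains why these numbers lie so close together.

The compounds shown leave open whether any other group on this ring, such as a methoxy or a nitro group, would move the growth inhibition beyond the usual scatter, or whether a larger change at this end of the molecule, such as a carboxylic acid in place of the phenyl ring, would do so. They also leave open how a longer chain in the shared core would compare, and how all of these compounds would rank at other concentrations.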